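A few compounds are considered here, and "the series" means these few. Any claim that something is new, unique, unknown or untested is made for them only; others in the source may bear on it.

Among the measured compounds shown here, in a functional assay on K562 cells (Homo sapiens) for cytotoxicity, read by trypan blue exclusion, with a stated time of 96 h (a higher number here means a weaker inhibitor, a lower number a stronger inhibitor), compound 1 `COc1ccc(NS(=O)(=O)/C=C/c2cc(OC)c(OC)c(OC)c2)cc1` gives 35000 nM, the higher of the two numbers available so far. Compound 2 `COc1ccc(NS(=O)(=O)/C=C/c2c(F)cc(F)cc2F)cc1` gives 15000 nM, a lower number than compound 1 by a margin beyond the usual scatter. Compound 1 is therefore the weaker inhibitor of this pair.

Compound 3 `COc1ccc(NS(=O)(=O)/C=C/c2cc(OC)c(OC)c(OC)c2)cc1[N+](=O)[O-]` is the open case. It keeps the core of compound 1 but carries nitro in place of hydrogen on an aromatic carbon. The new group sits ortho to a methoxy group and meta to a large group.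

For the measured compounds named here, no measured pair isolates this change, so the direction of the step is uncertain and the range has to stay wide. A moderate step toward a lower number in this assay is expected, probably beyond the scatter, since compound 1 at 35000 nM is the higher of the two values. The estimate corresponds to an expected 2.9-fold lower number from compound 1 to compound 3 (0.46 log units; beyond the scatter). For compound 3 the estimated value is 12000 nM, with an expected range of 2000 nM to 40000 nM.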

Compound 3, half-maximal inhibitory concentration: 75000 nM
Compound 3: middle estimate off by 6.3-fold (0.80 log units), on the low side, outside the stated range (above it).
By their numbers in this assay, from the lowest: compound 2; then compound 1; then compound 3.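

Nitro in place of hydrogen on an aromatic carbon, ortho to a methoxy group and meta to a large group, produces a 2.1-fold higher number from compound 1 to compound 3 (0.33 log units; beyond the scatter) in this assay and so moves the core of compound 1 toward weaker inhibition. Among the compounds shown here, this is the only step so far that isolates a single change, and it gives this position a measured direction: here, a hydrogen replaced by nitro raises the number by a modest amount that still lies beyond the scatter. The compounds shown offer no measurement that accounts for this rise.

As far as these compounds go, whether an amine, a carboxylic acid or a nitrile at the same place would also raise the number, or would lower it, remains open, so one substituent cannot yet define a trend for this position. Also open, from the compounds shown here alone, is whether nitro would produce a step of similar direction and size on the core of compound 2, and whether the step seen here carries over to any read-out other than this assay.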